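This account rests on a few compounds, and the source may have more. Where it says the series, first, only, none or still open, it means among the compounds named here.

Compound 1 `CC(C)=CCC/C(C)=C/CC/C(C)=C/CSc1ccccc1C(=O)N[C@@H](C)C(=O)OCCCCOc1no[n+]([O-])c1S(=O)(=O)c1ccccc1` gives 7950 nM in a functional assay on U-251 cells (Homo sapiens) for cytotoxicity, read by MTT assay, with a stated time of 48 h; on this read-out higher numbers stand for weaker inhibition and lower numbers for stronger inhibition. Compound 2 `CC(C)=CCC/C(C)=C/CC/C(C)=C/CSc1ccccc1C(=O)N[C@@H](C)C(=O)OCCOCCOc1no[n+]([O-])c1S(=O)(=O)c1ccccc1` gives 8040 nM in this assay. Compound 3 `CC(C)=CCC/C(C)=C/CC/C(C)=C/CSc1ccccc1C(=O)NCC(=O)OCCCCOc1no[n+]([O-])c1S(=O)(=O)c1ccccc1` gives 28200 nM in this assay.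

Compounds 1 and 2 differ in their cores, and that difference is not broken down here; their two values lie within the scatter of each other. From compound 1 to compound 3 the change is hydrogen in place of methyl on a saturated chain carbon bound to an amide-type nitrogen and a carbonyl carbon, and this step gives a 3.5-fold higher number from compound 1 to compound 3 (0.55 log units; beyond the scatter).

Compound 4 `CC(C)=CCC/C(C)=C/CC/C(C)=C/CSc1ccccc1C(=O)NCC(=O)OCCOCCOc1no[n+]([O-])c1S(=O)(=O)c1ccccc1` has not yet been measured in this assay. It differs from compound 2 by hydrogen in place of methyl on a saturated chain carbon bound to an amide-type nitrogen and a carbonyl carbon, the same change that turns compound 1 into compound 3, at the same place. Among the measured compounds shown here, since compound 2 sits within the scatter of compound 1 in this assay, the step from compound 2 to compound 4 is expected to be close in size to the earlier one, because a 3.5-fold higher number from compound 1 to compound 3 (0.55 log units; beyond the scatter) is the only measured example of this change. Compound 4 is therefore estimated at 28000 nM, with a range from 14000 nM to 56000 nM, which means an expected step of a 3.5-fold higher number from compound 2 to compound 4 (0.54 log units; beyond the scatter).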

Compound 4, half-maximal inhibitory concentration: 8580 nM
Beside the measured number, compound 4's estimate is 3.3-fold (0.51 log units) above it; the measured number lies below the stated range.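

Putting hydrogen in place of methyl on a saturated chain carbon bound to an amide-type nitrogen and a carbonyl carbon did not have the same outcome on both cores in this assay, where the change now gives a 1.1-fold higher number from compound 2 to compound 4 (0.03 log units; within the scatter). The two measured examples of this change disagree: the same change on two cores in this assay, a 3.5-fold higher number (0.55 log units; beyond the scatter) from compound 1 to compound 3 and a 1.1-fold higher number (0.03 log units; within the scatter) from compound 2 to compound 4, 3.3-fold (0.52 log units) apart, beyond the scatter of two such steps. This shows that the size of the step on the core of compound 1 cannot be carried to the core of compound 2 in this series, but two pairs do not show which feature of the cores goes with the difference, or what size the step would take on any further core.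

The compounds shown leave open whether an ethyl or benzyl group at this place would follow the core of compound 1 or the core of compound 2. They also leave open how either core would respond if the ester gave way to an amide or a carboxylic acid, or if a longer chain were used.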